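This account rests on a few compounds, and the source may have more. Where it says the series, first, only, none or still open, it means among the compounds named here.

In a functional assay on MV4-11 cells (Homo sapiens) for antiproliferative activity (on this read-out higher numbers stand for weaker inhibition and lower numbers for stronger inhibition), compound 1 `Cc1ccc(C(=O)Nc2sc3c(c2C(N)=O)CCCC3)cc1` gives 450 nM, compound 2 `NC(=O)c1c(NC(=O)c2ccc(Cl)cc2)sc2c1CCCC2` gives 1400 nM and compound 3 `CC(=O)c1ccc(C(=O)Nc2sc3c(c2C(N)=O)CCCC3)cc1` gives 1800 nM. Compound 3 therefore stands level with compound 2, at a 1.3-fold higher number from compound 2 to compound 3 (0.11 log units; within the scatter), and clearly apart from compound 1, at a 4.0-fold higher number from compound 1 to compound 3 (0.60 log units; beyond the scatter). The next compound, compound 4 `CC(C)(C)c1ccc(C(=O)Nc2sc3c(c2C(N)=O)CCCC3)cc1`, has tert-butyl in place of acetyl on an aromatic carbon.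

Among the compounds with values here, no measured step involves tert-butyl, so the bearing evidence is indirect. The closest guide is the replacement of methyl at this same place, which gave a 4.0-fold higher number from compound 1 to compound 3 (0.60 log units; beyond the scatter) with acetyl and a 3.1-fold higher number from compound 1 to compound 2 (0.49 log units; beyond the scatter) with chloro. Both are modest steps, and both run away from compound 1. Tert-butyl resembles the methyl of compound 1 in containing carbon only, so compound 4 is expected to move back toward compound 1 in this assay, though perhaps not all the way, as the larger group remains untested here. The expected change is modest and toward stronger inhibition, at a 2.6-fold lower number from compound 3 to compound 4 (0.41 log units; beyond the scatter). For compound 4 the estimated value is 700 nM, with an expected range from 250 nM to 2000 nM.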

Compound 4, half-maximal inhibitory concentration: 1600 nM
Compound 4: the middle estimate sits 2.3-fold (0.36 log units) below what was measured, and the stated range covers the measured number.
By their numbers in this assay, from the lowest: compound 1; then compounds 2, 4 and 3 (each within the scatter of the next).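

In this assay, tert-butyl and acetyl cannot be told apart on an aromatic carbon para to a large group, with a 1.1-fold lower number from compound 3 to compound 4 (0.05 log units; within the scatter) as the step, and tert-butyl and chloro also stand level, with a 1.1-fold higher number from compound 2 to compound 4 (0.06 log units; within the scatter) as their step. The comparison with methyl is the new finding: a 3.6-fold higher number from compound 1 to compound 4 (0.55 log units; beyond the scatter) shows that a group of carbon only does not by itself keep the number of compound 1, so compound 1 alone stands apart from the other three compounds, which form one level group with no order among them. The data offer no measured basis for explaining this separation.

The compounds shown leave open whether the lower number belongs to methyl alone or would extend to ethyl or isopropyl, and whether methoxy, an amine or a carboxylic acid at this place would join compound 1 or the level group. They also leave open whether the same separation would hold if the shared core were changed elsewhere.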